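Halogen position shift on a benzylthio purine nucleoside

This account rests on a few compounds, and the source may have more. Where it says the series, first, only, none or still open, it means among the compounds named here.

Measured compounds:
- compound 1, `CC(C)(Sc1ncnc2c1ncn2[C@@H]1O[C@H](CO)[C@@H](O)[C@H]1O)c1ccccc1`, 21400 nM
- compound 2, `Nc1nc(SCc2cccc(Br)c2)c2ncn([C@@H]3O[C@H](CO)[C@@H](O)[C@H]3O)c2n1`, 2880 nM

In an assay on isolated protein for binding affinity to Equilibrative nucleoside transporter 1 (Homo sapiens) (a higher number here means a weaker inhibitor, a lower number a stronger inhibitor), compound 2 gives 2880 nM. This is the lower of the two numbers recorded; compound 1 gives 21400 nM in this assay, a higher number that lies beyond the scatter, so compound 2 is the stronger inhibitor of the pair. The two compounds differ in several places at once, so their gap cannot be tied to any single change.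

Compound 3, `Nc1nc(SCc2ccccc2Cl)c2ncn([C@@H]3O[C@H](CO)[C@@H](O)[C@H]3O)c2n1`, is built from compound 2 by a single swap: 2-chlorophenyl in place of 3-bromophenyl on a saturated chain carbon bound to a sulfur. The ring and the count of heavy atoms, donors and acceptors are unchanged; only the halogen and where it sits on the ring move.

Going by the values given here, with no measured step of this kind among the two compounds, the expected change from compound 2 to compound 3 in this assay is a 1.4-fold higher number from compound 2 to compound 3 (0.14 log units; within the scatter), a small shift that is expected to stay near the scatter. Compound 3 is therefore expected to give 4000 nM, with a range from 1500 nM to 12000 nM.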

Compound 3, half-maximal inhibitory concentration: 13500 nM
For compound 3 the middle estimate is 3.4-fold (0.53 log units) below the measured one; the whole stated range lies below it.
By their numbers in this assay, from the lowest: compound 2; then compounds 3 and 1 (each within the scatter of the next).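

Going by these compounds alone, the single swap of 3-bromophenyl for 2-chlorophenyl on a saturated chain carbon bound to a sulfur gives the first step here that can be tied to one place in this assay (a 4.7-fold higher number from compound 2 to compound 3 (0.67 log units; beyond the scatter)), a link that the several differences between compound 1 and compound 2 could not provide. It shows that the number at this position responds to the halogen and where it sits on the ring, even though the count of heavy atoms, donors and acceptors stays the same. No measured evidence accounts for this step.

Because the halogen and its position change together, the compounds shown leave open how much of the step belongs to each, a question that 3-chlorophenyl and 2-bromophenyl at the same place could separate. Also open, as far as these compounds go, is how this position would respond to a different kind of group, such as a methoxy group or an amine on the phenyl ring, or a longer chain between the sulfur and the ring.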